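Compound 1 to compound 3: ethoxycarbonyl to methylcarbamoyl

The source may report more compounds than this note shows. Statements on the series, on what has been measured and on what is new or still open speak of the compounds shown alone.

Measured in an ADME assay on J774 cells (Mus musculus) for cytotoxicity (on this read-out higher numbers stand for an effect only at larger amounts of compound and lower numbers for an effect already at smaller amounts), compound 1 (`CCCCc1cc2c(=O)c(C(=O)OCC)c[nH]c2cc1OCCOc1ccccc1`) gives > 20000 nM as its reading, which is a limit of the assay and not a number. Compound 2 (`CCc1cc2c(=O)c(C(=O)OC)c[nH]c2cc1OCCOc1ccccc1`) gives > 20000 nM as its reading, again a limit and not a number. Compound 1 thus stands with compound 2 at the limit of > 20000 nM in this assay, at which 2 of the 2 values shown sit, and neither has an exact value.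

Compound 3 (`CCCCc1cc2c(=O)c(C(=O)NC)c[nH]c2cc1OCCOc1ccccc1`) has not yet been measured. It carries methylamino in place of ethoxy on a carbonyl carbon of compound 1 (methylamino in place of ethoxy on a carbonyl carbon), so ethoxycarbonyl gives way to methylcarbamoyl. No measured step sizes this change. The expected step of a number no higher from compound 1 to compound 3 (the limit leaves the size open) in this assay is none beyond the scatter. For compound 3 the estimated value is 20000 nM with an expected range from 10000 nM to 40000 nM on this read-out.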

Compound 3, half-maximal effective concentration: > 20000 nM
Compound 3 was reported as a limit; the forecaster's own chance of this, stated with the estimate: 75%; the middle value sits exactly at the limit.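

In this assay no step can be read from compound 1 to compound 3, because both readings are limits and not numbers: the limit of > 20000 nM in this assay, at which 3 of the 3 values shown sit.

The compounds shown leave open whether methylcarbamoyl in place of ethoxycarbonyl changes the reading at all; none of them has an exact value.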